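Moving the Hydroxyl Group on a Shared Core

This account rests on a few compounds, and the source may have more. Where it says the series, first, only, none or still open, it means among the compounds named here.

Compound 1 `Oc1cccc(-c2cc(-c3cccs3)cc(-c3ccccc3O)n2)c1`: > 50000 nM in a functional assay on HeLa cells (Homo sapiens) for cytotoxicity, read by CCK-8 assay (a lower number here means a stronger inhibitor, a higher number a weaker inhibitor), a limit of the assay.
Compound 2 `Oc1ccc(-c2cc(-c3cccs3)cc(-c3ccccc3O)n2)cc1`: > 50000 nM in this assay, also a limit of the assay.
Compound 3 `Oc1ccc(-c2cc(-c3ccco3)cc(-c3cccc(O)c3)n2)cc1`: 5170 nM in this assay.

Compound 1 and compound 2 differ by 4-hydroxyphenyl in place of 3-hydroxyphenyl on an aromatic carbon. The step that the two limits leave unreadable from compound 1 to compound 2 cannot be read, because of the limit of > 50000 nM in this assay, at which 2 of the 3 values shown sit. Compound 4 `Oc1ccc(-c2cc(-c3ccco3)cc(-c3ccc(O)cc3)n2)cc1`, not yet measured, differs from compound 3 by 4-hydroxyphenyl in place of 3-hydroxyphenyl on an aromatic carbon. This is the same kind of change as that between compound 1 and compound 2, though the surroundings differ: in compound 1 the place is meta to a 2-hydroxyphenyl group and meta to a thiophen-2-yl group, in compound 3 it is meta to a 4-hydroxyphenyl group and meta to a furan-2-yl group. How the core of compound 1 and the core of compound 3 differ is not broken down here. With the earlier step unreadable, the step from compound 3 is expected to be small, a 1.2-fold higher number from compound 3 to compound 4 (0.06 log units; within the scatter). Compound 4 is estimated at 6000 nM in this assay, between 2000 nM and 25000 nM.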

Compound 4, half-maximal inhibitory concentration: > 50000 nM
Compound 4: only a limit was reported (the forecaster's own chance of this, stated with the estimate: 25%); middle value at least 8.3-fold (0.92 log units) away from the limit.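

In this assay, 4-hydroxyphenyl in place of 3-hydroxyphenyl on the core of compound 3 gives an at least 9.6-fold higher number from compound 3 to compound 4 (0.98 log units; beyond the scatter). Compound 4 gives > 50000 nM, which is a limit of the assay. The same change on the core of compound 1 cannot be read, so this single readable step does not show whether the change carries from one core to the other, because the values pile up at one limit: the limit of > 50000 nM in this assay, at which 3 of the 4 values shown sit.

The compounds shown leave open whether an amine or a methoxy group in place of the hydroxyl on this ring would keep the reading of compound 3. They also leave open what thiophen-2-yl in place of furan-2-yl does on its own, with everything else on the core unchanged.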